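Swapping a Halogenated Phenyl on the Shared Core

A few compounds are considered here, and "the series" means these few. Any claim that something is new, unique, unknown or untested is made for them only; others in the source may bear on it.

Of the compounds shown here, three sharing one core have been tested in a functional assay on K562 cells (Homo sapiens) for antiproliferative activity, read by MTT assay, with a stated time of 72 h (a lower number here means a stronger inhibitor, a higher number a weaker inhibitor), and all three sit at the same edge of what the assay can report. Compound 1 `COc1cc(-n2ncnc2-c2cccc([N+](=O)[O-])c2)cc(OC)c1OC` gives > 10000 nM, which is a limit of the assay rather than a number. Compound 2 `COc1cc(-n2ncnc2-c2cccc(F)c2)cc(OC)c1OC` gives > 10000 nM, again a limit. Compound 3 `CCOc1cccc(-c2ncnn2-c2cc(OC)c(OC)c(OC)c2)c1` gives > 10000 nM, once more a limit. Because of the limit of > 10000 nM in this assay, at which 3 of the 3 values shown sit, the three steps among them, a step that the two limits leave unreadable from compound 1 to compound 2, a step that the two limits leave unreadable from compound 1 to compound 3 and a step that the two limits leave unreadable from compound 2 to compound 3, cannot be sized: two limits do not yield a readable difference.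

Compound 2 therefore stands nowhere in particular on the numbers shown; it shares its limit with both companions, and no order among the three can be stated.

The next compound, compound 4 `COc1cc(-n2ncnc2-c2ccc(Cl)c(Cl)c2)cc(OC)c1OC`, differs from compound 2 by 3,4-dichlorophenyl in place of 3-fluorophenyl on an aromatic carbon. Within the data shown here, no measured step speaks to this change, since every step so far is unreadable. Among the measured compounds shown here, the only guidance is that three variations at this position all ended at the limit. Compound 4 is therefore expected to show a step that the limit leaves unreadable from compound 2 to compound 4, meaning no shift beyond the scatter. The estimate for compound 4 is 12000 nM, within a range from 2000 nM to 60000 nM.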

Compound 4, half-maximal inhibitory concentration: > 10000 nM
Compound 4: a limit, no number (the forecaster's own chance of this, stated with the estimate: 70%); the middle value does not contradict the limit.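

Among these compounds, compound 4 ends at a limit of the assay rather than a number, just as compound 2 does, and no step between them can be read, because all the values rest on the same limit: the limit of > 10000 nM in this assay, at which 4 of the 4 values shown sit. The compounds shown leave open how the four rank against one another, and whether any substituted phenyl at this place on the shared core can give a real number in this assay.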